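Isopropyl in Place of Methyl on the Amide-Type Nitrogen

This account rests on a few compounds, and the source may have more. Where it says the series, first, only, none or still open, it means among the compounds named here.

Compound 1, `CN(O)C(=O)CCSc1nc2ccccc2s1`: 39 nM
Compound 2, `CN(O)C(=O)CSc1nc2ccccc2s1`: 70 nM
Compound 3, `CN(O)C(=O)NCCSc1nc2ccccc2s1`: 90 nM

Among the compounds with values here, in a functional assay for inhibition of Polyunsaturated fatty acid 5-lipoxygenase (Homo sapiens) (a higher number here means that more compound is needed for the effect, a lower number that less compound is needed), compound 3 gives the highest number of the three; compound 2 is within the scatter of it, and the only single-point step measured, a 2.3-fold higher number from compound 1 to compound 3 (0.36 log units; beyond the scatter), runs along the chain. Compound 4, `CC(C)N(O)C(=O)NCCSc1nc2ccccc2s1`, differs from compound 3 by isopropyl in place of methyl on an amide-type nitrogen. Within the data shown here, no measured step touches that nitrogen's substituent, so nothing measured bears directly on this change, and the step in this assay is expected to be a 1.1-fold higher number from compound 3 to compound 4 (0.05 log units; within the scatter), not beyond the scatter in either direction. Compound 4 is therefore estimated at 100 nM, with a range from 40 nM to 250 nM.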

Compound 4, half-maximal effective concentration: 130 nM
Compound 4: the middle estimate sits 1.3-fold (0.11 log units) below what was measured; measured number inside the range.
By their numbers in this assay, from the lowest: compounds 1, 2, 3 and 4 (each within the scatter of the next, the first and the last beyond it).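

In this assay, isopropyl in place of methyl on the amide-type nitrogen gives a 1.4-fold higher number from compound 3 to compound 4 (0.16 log units; within the scatter) and so stays within the scatter. Within the data shown here, this is the first measured change at this nitrogen's substituent, and it shows that the position accepts the larger alkyl group with no step beyond the scatter. Nothing available explains this result.

On these data alone, whether a tert-butyl, a phenyl or a chain ending in an amine or a carboxylic acid would stay as close to compound 3 remains open. Also open, as far as these compounds go, is whether isopropyl would give a similar step on the chain of compound 1.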